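The compounds below may be only part of what the source reports. "The series", "measured", "known", "first", "only" and "open" are said of these compounds alone.

Three compounds share one core and were tested for cytotoxicity. Compound 1 `Cc1ccc(-c2nnc(N3CCN(C(=O)CN4CCN(c5ccccc5)CC4)CC3)nc2-c2ccc(C)cc2)cc1` gives 914000 nM in a functional assay on MCF7 cells (Homo sapiens) for cytotoxicity, read by MTT assay, with a stated time of 24 h; on this read-out lower numbers stand for stronger inhibition and higher numbers for weaker inhibition. Compound 2 `Cc1ccc(-c2nnc(N3CCN(C(=O)CN4CCN(c5ccccc5Cl)CC4)CC3)nc2-c2ccc(C)cc2)cc1` gives 859000 nM in this assay, and compound 3 `COc1cccc(N2CCN(CC(=O)N3CCN(c4nnc(-c5ccc(C)cc5)c(-c5ccc(C)cc5)n4)CC3)CC2)c1` gives 867000 nM in this assay; compound 3 thus sits among three numbers that all lie within the scatter of one another. Compound 4 `Cc1ccc(-c2nnc(N3CCN(C(=O)CN4CCN(c5cccc(Cl)c5)CC4)CC3)nc2-c2ccc(C)cc2)cc1` differs from compound 3 by chloro in place of methoxy on an aromatic carbon. Among the measured compounds shown here, the steps that bear on this change are a 1.1-fold lower number from compound 1 to compound 3 (0.02 log units; within the scatter), a 1.1-fold lower number from compound 1 to compound 2 (0.03 log units; within the scatter) and a 1.0-fold higher number from compound 2 to compound 3 (0.00 log units; within the scatter), each within the scatter, so no step beyond the scatter in this assay is expected in either direction. The estimate for compound 4 is 870000 nM, ranging from 600000 nM to 1300000 nM. This corresponds to an expected step of a 1.0-fold higher number from compound 3 to compound 4 (0.00 log units; within the scatter).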

Compound 4, half-maximal inhibitory concentration: 797000 nM
Compound 4: middle estimate off by 1.1-fold (0.04 log units), on the high side, and the stated range covers the measured number.
By their numbers in this assay, from the lowest: compounds 4, 2, 3 and 1 (each within the scatter of the next).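

In this assay, chloro on this aromatic carbon, meta to a large group, reads no differently from methoxy (a 1.1-fold lower number from compound 3 to compound 4 (0.04 log units; within the scatter)). The 3-chlorophenyl group also matches the 2-chlorophenyl group (a 1.1-fold lower number from compound 2 to compound 4 (0.03 log units; within the scatter)), and chloro in place of hydrogen at this position leaves the number within the scatter as well (a 1.1-fold lower number from compound 1 to compound 4 (0.06 log units; within the scatter)). Nothing measured here accounts for this insensitivity. From the compounds shown here alone, whether an amine or a carboxylic acid on this ring would move the number beyond the scatter remains open, as does the effect of changes elsewhere on the shared core.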